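Trimming the aryl ether: expected cytotoxicity of compound 3

The source may hold more compounds than are shown below. What is called first, only, known or untested is meant among the compounds shown, and "the series" means these compounds.

In an ADME assay on MT4 cells (Homo sapiens) for cytotoxicity, read by MTT assay, with a stated time of 4 days (a lower number here means that less compound is tolerated, a higher number that more compound is tolerated), compound 1 `Cc1cccc(C)c1Oc1nc(Nc2ccc(C#N)cc2)nc2ccccc12` gives 35000 nM. For compound 2 `Cc1cc(C)c(Oc2nc(Nc3ccc(C#N)cc3)nc3ccccc23)c(C)c1` the same assay returns only a limit, > 34000 nM. The step that the limit leaves unreadable from compound 1 to compound 2, a methyl in place of hydrogen on an aromatic carbon, therefore cannot be read in size; the cause is the limit of > 34000 nM in this assay, at which 1 of the 2 values shown sits. Compound 3 `Cc1ccccc1Oc1nc(Nc2ccc(C#N)cc2)nc2ccccc12` has not yet been measured in this assay. Its change from compound 2 is 2-methylphenyl in place of 2,4,6-trimethylphenyl on an oxygen on an aromatic ring. Going by the values given here, the only measured step, from compound 1 to compound 2, touches the same ring, but its size is hidden by the limit, so it sets no direction for the change to 2-methylphenyl. Because compound 1 gives 35000 nM on this ring, compound 3 is expected to stay close to that figure, with the step of an at least 1.1-fold lower number from compound 2 to compound 3 (0.05 log units; that floor lies within the scatter) judged as none beyond the scatter. Compound 3 is therefore estimated at 30000 nM, within the range 10000 nM to 90000 nM.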

Compound 3, half-maximal cytotoxic concentration: 355000 nM
Compound 3: middle estimate off by 12-fold (1.07 log units), on the low side; measured number above the stated range.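

Until now the ring on the oxygen had given no readable step in this assay, but hydrogen in place of methyl on an aromatic carbon gives a 10-fold higher number from compound 1 to compound 3 (1.01 log units; beyond the scatter), so for this pair the read-out depends on what this ring carries. For compound 2, the value > 34000 nM is a limit of the assay and not a number. The steps that involve compound 2 cannot be read, so the effect of 2,4,6-trimethylphenyl relative to 2-methylphenyl stays undetermined: the limit of > 34000 nM in this assay, at which 1 of the 3 values shown sits.

The compounds shown carry only methyl groups on this ring, which leaves open how an ethyl, a methoxy or a chloro group in their place would move the number. Going by these compounds alone, they also leave open what an unsubstituted phenyl on the oxygen would give, and whether the single readable step would hold on another core.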